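A methoxy gives way to amino on the cinnamate

The source may report more compounds than this note shows. Statements on the series, on what has been measured and on what is new or still open speak of the compounds shown alone.

Measured in a functional assay on HCT-116 cells (Homo sapiens) for inhibition; a higher number here means a weaker inhibitor, a lower number a stronger inhibitor:
Compound 1 `COc1cc2oc(=O)cc(COC(=O)/C=C/c3ccccc3)c2cc1OC`: > 10 ug/mL (a limit)
Compound 2 `COc1ccc(/C=C/C(=O)OCc2cc(=O)oc3cc(OC)c(OC)cc23)cc1`: 1.02 ug/mL

For the measured compounds named here, compound 2, at 1.02 ug/mL, holds the only actual number in this assay. The result for compound 1 is a limit. Compound 3 `COc1cc2oc(=O)cc(COC(=O)/C=C/c3ccc(N)cc3)c2cc1OC` has amino in place of methoxy on an aromatic carbon. Going by the values given here, one measured step bears on this change: putting methoxy in place of hydrogen gave an at least 9.8-fold lower number from compound 1 to compound 2 (0.99 log units; beyond the scatter). Amino is not hydrogen, so only part of that gain is expected to be lost. The expected change is a 2.5-fold higher number from compound 2 to compound 3 (0.39 log units; beyond the scatter), towards a weaker inhibitor. For compound 3 the estimated value is 2.5 ug/mL, with an expected range of 0.6 ug/mL to 10 ug/mL.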

Compound 3, half-maximal inhibitory concentration: > 10 ug/mL
Compound 3: a limit, no number; the forecaster's own chance of this, stated with the estimate: 15%; middle value at least 4.0-fold (0.60 log units) away from the limit.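

Amino in place of methoxy on this aromatic carbon gave an at least 9.8-fold higher number from compound 2 to compound 3 (0.99 log units; beyond the scatter) in this assay, so the activity seen with 4-methoxyphenyl does not carry over to 4-aminophenyl. Among the compounds shown, only the methoxy group gives an actual number. The step between the hydrogen and amino compounds cannot be read, and neither limit shows how weak those compounds are: the limit of > 10 ug/mL in this assay, at which 2 of the 3 values shown sit.

As far as these compounds go, it remains open whether an ethoxy group, a hydroxyl or a chlorine at this place would keep the activity of compound 2.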